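A few compounds are considered here, and "the series" means these few. Any claim that something is new, unique, unknown or untested is made for them only; others in the source may bear on it.

Measured in a functional assay on HT-29 cells (Homo sapiens) for inhibition, read by luminescence and CellTiter-Glo, with a stated time of 24 h; on this read-out lower numbers stand for an effect already at smaller amounts and higher numbers for an effect only at larger amounts of compound:
- compound 1 `CN1C(=S)[C@@H](NC(=O)c2nc(Cc3ccccc3)n(C)n2)COc2ccccc21`: 2.5 nM
- compound 2 `CCCn1nc(C(=O)N[C@H]2COc3ccccc3N(C)C2=S)nc1Cc1ccccc1`: 288 nM

Of these two, compound 2 has the higher number, so it needs the larger amount of compound for its effect. Compound 3 `CCCCn1nc(C(=O)N[C@H]2COc3ccccc3N(C)C2=S)nc1Cc1ccccc1` has not been measured yet. It turns the propyl of compound 2 into butyl: methyl in place of hydrogen on a saturated chain carbon, three bonds along the chain from an aromatic nitrogen. For the measured compounds named here, only one measured step bears on this change, and it lies on the same chain, where ethyl replaces hydrogen on a saturated chain carbon bound to an aromatic nitrogen. That step, a 120-fold higher number from compound 1 to compound 2 (2.06 log units; beyond the scatter), is large and beyond the scatter. A single step cannot show whether the trend continues, and the addition here is only methyl. The expected change is a 2.8-fold higher number from compound 2 to compound 3 (0.44 log units; beyond the scatter), in the same direction but much smaller. For compound 3 the estimate is 800 nM, with an expected range of 200 nM to 3000 nM.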

Compound 3, half-maximal effective concentration: 510 nM
Compound 3: the middle estimate sits 1.6-fold (0.20 log units) above what was measured; low and high end bracket the measured number.
By their numbers in this assay, from the lowest: compound 1; then compounds 2 and 3 (each within the scatter of the next).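

Adding a methyl to the end of the propyl chain to give butyl makes no clear difference (a 1.8-fold higher number from compound 2 to compound 3 (0.25 log units; within the scatter)), so compound 2 and compound 3 cannot be told apart here. The large gap to compound 1 therefore remains with butyl (a 200-fold higher number from compound 1 to compound 3 (2.31 log units; beyond the scatter)), and the earlier step alone could not show that this further addition would have no effect beyond the scatter. No available evidence explains this behaviour at the chain.

The compounds shown leave open how an intermediate ethyl chain would compare, and so at what length the large step arises. Also open, on these data alone, is whether a longer chain such as hexyl, a branched chain such as isopropyl, or a chain ending in an amine or a carboxylic acid would behave like propyl and butyl.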